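This account rests on a few compounds, and the source may have more. Where it says the series, first, only, none or still open, it means among the compounds named here.

Measured so far:
- compound 1, `CCCn1c(=O)c2[nH]c(C34CCC(C(=O)NCCCNC(=O)COCCNC(=O)OC(C)(C)C)(CC3)CC4)nc2n(CCC)c1=O`: 16.2 nM
- compound 2, `CCCn1c(=O)c2[nH]c(C34CCC(CCC(=O)NCCNC(=O)COCCNC(=O)OC(C)(C)C)(CC3)CC4)nc2n(CCC)c1=O`: 14.8 nM

Both compounds share the same core and differ only in the flexible chain that carries the terminal carbamate. In an assay on Flp-In-CHO cells for displacement of a labelled ligand from adenosine receptor A1 (Homo sapiens), read by radioligand binding (a lower number here means a stronger inhibitor, a higher number a weaker inhibitor), compound 1 gives 16.2 nM and compound 2 gives 14.8 nM. Compound 2 has the smaller of the two numbers, yet the gap to compound 1 is within the scatter, so the two compounds cannot be told apart on these data.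

Compound 3 is `CCCn1c(=O)c2[nH]c(C34CCC(CCC(=O)NCCNC(=O)COCCOCCNC(=O)OC(C)(C)C)(CC3)CC4)nc2n(CCC)c1=O`. It is derived from compound 2 by one change: 2-((tert-butoxycarbonyl)amino)ethoxy in place of (tert-butoxycarbonyl)amino on a saturated chain carbon, two bonds along the chain from an oxygen on a saturated carbon. The change lengthens the chain at its far end, away from the core, and keeps the carbamate as the terminal group.

Since compound 1 and compound 2 already show that a different chain leaves the result within the scatter, no step beyond the scatter is expected here either. The expected step of a 1.0-fold higher number from compound 2 to compound 3 (0.01 log units; within the scatter) is essentially none. Compound 3 is expected to give 15 nM, with a likely range from 6 nM to 40 nM.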

Compound 3, inhibition constant: 13.2 nM
Estimate against measurement, compound 3: 1.1-fold (0.06 log units) above; the range from low to high includes it.
By their numbers in this assay, from the lowest: compounds 3, 2 and 1 (each within the scatter of the next).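

Among the compounds shown here, replacing (tert-butoxycarbonyl)amino with 2-((tert-butoxycarbonyl)amino)ethoxy, on a saturated chain carbon, two bonds along the chain from an oxygen on a saturated carbon, gives the first step here that can be tied to one place. In this assay the result is a 1.1-fold lower number from compound 2 to compound 3 (0.05 log units; within the scatter) for this change, so this place takes the larger group, with the same terminal carbamate, without a difference that the assay can resolve. No measurement at hand accounts for this result.

All three compounds end in the same carbamate, so they leave open whether a free amine or a carboxylic acid at the end of the chain would also give a number within the scatter of compound 3. They also leave open how far the chain can grow, as a single extension cannot show whether a longer chain with further ethoxy units would behave the same way.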